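Fluoro on the fused ring of compound 1: next position

The source may hold more compounds than are shown below. What is called first, only, known or untested is meant among the compounds shown, and "the series" means these compounds.

Compound 1 `C#Cc1cc(-c2nc3ccccc3s2)ccc1N` gives 49 nM in a functional assay on MCF7 cells (Homo sapiens) for inhibition, with a stated time of 72 h (a lower number here means a stronger inhibitor of growth, a higher number a weaker inhibitor of growth), the lowest of the two numbers in hand; nearest stands compound 2 `C#Cc1cc(-c2nc3c(F)cccc3s2)ccc1N`, which gives 110 nM in this assay. Compound 3 `C#Cc1cc(-c2nc3ccc(F)cc3s2)ccc1N` differs from compound 1 by fluoro in place of hydrogen on an aromatic carbon. Within the data shown here, the only step that bears on this is a 2.2-fold higher number from compound 1 to compound 2 (0.35 log units; beyond the scatter), a fluoro entering at another aromatic carbon of the shared core. A modest rise of similar size is therefore expected for compound 3 in this assay, namely a 1.7-fold higher number from compound 1 to compound 3 (0.24 log units; within the scatter). Compound 3 is estimated at 85 nM, within 35 nM to 200 nM.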

Compound 3, concentration for 50% growth inhibition: 110 nM
Compound 3: the middle estimate sits 1.3-fold (0.11 log units) below what was measured; low and high end bracket the measured number.
By their numbers in this assay, from the lowest: compound 1; then compounds 2 and 3 (each within the scatter of the next).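

In this assay, fluoro on this aromatic carbon, meta to a fused ring and para to a fused ring, gives a 2.2-fold higher number from compound 1 to compound 3 (0.35 log units; beyond the scatter), so the rise is not confined to the carbon of the earlier step, a 2.2-fold higher number from compound 1 to compound 2 (0.35 log units; beyond the scatter). Across the two fluoro compounds shown, neither step lowers the number from compound 1. Nothing available accounts for this rise.

Open, as far as these compounds go, is whether a group other than fluoro on this carbon, such as chloro, methoxy or an amine, would move the number in the same direction.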